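A Methoxy Addition to a Potent Hydrazone

The source may hold more compounds than are shown below. What is called first, only, known or untested is meant among the compounds shown, and "the series" means these compounds.

Compound 1 `Cc1csc(N/N=C/c2ccccc2)n1`: 1.32 nM
Compound 2 `C(=N/Nc1nc(-c2ccccc2)cs1)\c1ccccc1`: 91.2 nM

Among the measured compounds shown here, in an assay on mitochondria for inhibition of Amine oxidase [flavin-containing] B (Bos taurus) (on this read-out lower numbers stand for stronger inhibition and higher numbers for weaker inhibition), compound 1 stands lowest of the two numbers; its only neighbour is compound 2, which lies far higher. For the measured compounds named here, the single measured step, a 69-fold higher number from compound 1 to compound 2 (1.84 log units; beyond the scatter), concerns a different site of the shared core and does not bear on the change considered here. Compound 3 `COc1ccc(/C=N/Nc2nc(C)cs2)cc1` differs from compound 1 by methoxy in place of hydrogen on an aromatic carbon. Going by the values given here, no measured step speaks to this change, so no shift beyond the scatter is expected; the estimated step is a 1.1-fold higher number from compound 1 to compound 3 (0.06 log units; within the scatter). Compound 3 is therefore expected to give about 1.5 nM, within 0.4 nM to 6 nM.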

Compound 3, inhibition constant: 4.07 nM
Beside the measured number, compound 3's estimate is 2.7-fold (0.43 log units) below it, within the range that was stated.
By their numbers in this assay, from the lowest: compound 1; then compound 3; then compound 2.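

Among the compounds shown here, until now, the only measured step in this assay concerned a different site of the shared core, so this is the first reading at the carbon para to the group of 9 heavy atoms on the six-membered aromatic ring. There, methoxy in place of hydrogen gives a 3.1-fold higher number from compound 1 to compound 3 (0.49 log units; beyond the scatter) and so weakens inhibition modestly, but measurably, while leaving it strong. No available evidence explains this shift. From the compounds shown here alone, whether a smaller or larger group at this same place, such as a hydroxyl, a chlorine or an amine, would raise the number further remains open.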